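Inverting a ring stereocentre in an antiproliferative series

The source may report more compounds than this note shows. Statements on the series, on what has been measured and on what is new or still open speak of the compounds shown alone.

Of the compounds shown here, three sharing one core have been measured in a functional assay on HCC827 cells (Homo sapiens) for antiproliferative activity, read by MTT assay, with a stated time of 72 h; on this read-out lower numbers stand for stronger inhibition and higher numbers for weaker inhibition. Compound 1 `CN1CCN(c2ccc(Nc3ncc4nc(Nc5ccccc5)n([C@H]5CCN(S(C)(=O)=O)C5)c4n3)cc2)CC1` gives 17 nM. Compound 3 `CN1CCN(c2ccc(Nc3ncc4nc(Nc5ccccc5)n([C@@H]5CCN(S(=O)(=O)C6CC6)C5)c4n3)cc2)CC1`, which carries 1-(cyclopropylsulfonyl)pyrrolidin-3-yl in place of 1-(methylsulfonyl)pyrrolidin-3-yl on an aromatic nitrogen, gives 0.88 nM; that single change produced a 19-fold lower number from compound 1 to compound 3 (1.29 log units; beyond the scatter). Compound 2 `CN1CCN(c2ccc(Nc3ncc4nc(Nc5ccc(F)cc5)n([C@H]5CCCC(NC(=O)OC(C)(C)C)C5)c4n3)cc2)CC1` gives 120 nM, the highest of the three numbers in this assay, standing beyond the scatter above both compound 1 and compound 3.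

Compound 4 `CN1CCN(c2ccc(Nc3ncc4nc(Nc5ccc(F)cc5)n([C@@H]5CCCC(NC(=O)OC(C)(C)C)C5)c4n3)cc2)CC1` has not yet been measured. It differs from compound 2 only in configuration: the two compounds have the same atoms and bonds; at least one stereo element is drawn with a configuration in one of them and without one in the other: 1 of 2 stereo elements differ; a stereocentre at a saturated ring carbon is drawn S in compound 2 and R in compound 4. Going by the values given here, no measured step bears on this kind of change; the one step known, from compound 1 to compound 3, swaps a substituent rather than a configuration, so it gives no guide to direction or size. With nothing to point either way, compound 4 is expected to sit close to the number of its diastereomer, with a wide range to allow for either configuration proving the more active, so the expected step is a 1.3-fold higher number from compound 2 to compound 4 (0.10 log units; within the scatter). Compound 4 is therefore estimated at 150 nM, expected to fall between 30 nM and 800 nM.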

Compound 4, half-maximal inhibitory concentration: 280 nM
Compound 4: the middle estimate sits 1.9-fold (0.27 log units) below what was measured; the measured number falls inside the stated range.
By their numbers in this assay, from the lowest: compound 3; then compound 1; then compound 2; then compound 4.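

In this assay, inverting this saturated ring carbon gives a 2.3-fold higher number from compound 2 to compound 4 (0.37 log units; beyond the scatter). Going by these compounds alone, with atoms and bonds unchanged, configuration alone therefore moves the number beyond the scatter, which the substituent swap among the earlier compounds could not show, and in this pair the S drawing carries the lower number, though the step is modest. The comparison carries one caution in how the pair is drawn: the fact that one of compounds 2 and 4 is drawn with a defined configuration and the other without, at the place where they differ

From the compounds shown here alone, whether the S drawing would still carry the lower number with a free primary amine or an acetamide in place of the tert-butyl carbamate remains open. Also open, going by these compounds, is whether the same inversion would shift the number by a similar amount in the compounds bearing 1-(methylsulfonyl)pyrrolidin-3-yl or 1-(cyclopropylsulfonyl)pyrrolidin-3-yl.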